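Removing the cyano group of compound 1: expected effect

The compounds below may be only part of what the source reports. "The series", "measured", "known", "first", "only" and "open" are said of these compounds alone.

Three compounds of this series carry numbers in a functional assay on HEK293 cells for agonist activity at D(4) dopamine receptor (Homo sapiens), read by FLIPR; on this read-out lower numbers stand for an effect already at smaller amounts and higher numbers for an effect only at larger amounts of compound. Compound 1 `N#Cc1cccc(C(=O)NCN2CCC(c3cccc[n+]3[O-])CC2)c1` gives 840 nM, the highest of the three. Compound 3 `CC(C)Oc1cccc(NC(=O)CN2CCC(c3cccc[n+]3[O-])CC2)c1` gives 555 nM, a number that lies within the scatter of compound 1. Compound 2 `Cc1ccc(Cl)c(NC(=O)CN2CCC(c3cccc[n+]3[O-])CC2)c1Cl` gives 346 nM, a lower number than compound 1 by more than the scatter. Among the compounds with values here, these three differ from one another in more than one place, so no single-change step between measured compounds can be read from them.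

Compound 4 `O=C(NCN1CCC(c2cccc[n+]2[O-])CC1)c1ccccc1` has not yet been measured in this assay. It differs from compound 1 by hydrogen in place of cyano on an aromatic carbon; cut one bond further out, 3-cyanophenyl becomes phenyl. Within the data shown here, no measured pair shows what the cyano contributes, so the expectation rests on the anchor alone. Compound 1 at 840 nM is that anchor. The expected step is a 1.3-fold higher number from compound 1 to compound 4 (0.12 log units; within the scatter), towards a higher number or none beyond the scatter. Compound 4 is estimated at 1100 nM, with a range from 450 nM to 2800 nM.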

Compound 4, half-maximal effective concentration: 532 nM
The estimate for compound 4 lay 2.1-fold (0.32 log units) above the measured number, and the stated range covers the measured number.
By their numbers in this assay, from the lowest: compounds 2, 4, 3 and 1 (each within the scatter of the next, the first and the last beyond it).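

In this assay, within the data shown here, compounds 1 and 4 form the first pair of the series that differs in one place only: hydrogen in place of cyano on an aromatic carbon, meta to a large group, gives a 1.6-fold lower number from compound 1 to compound 4 (0.20 log units; within the scatter) on going from 3-cyanophenyl to phenyl. At this position, then, the cyano group is not required for a number in this range, and this single pair shows no effect of the change beyond the scatter. Nothing available here bears on the reason for this result.

On these data alone, whether another group at the same place, such as an amine, a carboxylic acid or a methoxy group, would shift the number beyond the scatter remains open. Also open, as far as these compounds go, is whether cyano would give the same result elsewhere on this ring.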